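From 3-methylphenyl to 3-chloro-4-fluorophenyl on the sulfonamide

A few compounds are considered here, and "the series" means these few. Any claim that something is new, unique, unknown or untested is made for them only; others in the source may bear on it.

Of the compounds shown here, three have numbers so far. In a functional assay on DU-145 cells (Homo sapiens) for inhibition, read by CCK-8 assay, with a stated time of 72 h (on this read-out higher numbers stand for weaker inhibition and lower numbers for stronger inhibition), compound 1 (`O=C(/C=C/c1cccnc1)NCCCCCCCc1ccc(S(=O)(=O)Nc2ccccc2)cc1`) gives 438 nM and compound 2 (`O=C(/C=C/c1cccnc1)NCCCCCCCc1cccc(S(=O)(=O)Nc2ccccc2)c1`) gives 429 nM with the two values within the scatter of each other. Compound 3 (`Cc1cccc(NS(=O)(=O)c2cccc(CCCCCCNC(=O)/C=C/c3cccnc3)c2)c1`) gives 41.7 nM as the lowest of the three numbers, beyond the scatter from both of the others. Compound 3 differs from each of them in more than one place, so the gap cannot be assigned to any single change.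

Compound 4 (`O=C(/C=C/c1cccnc1)NCCCCCCc1cccc(S(=O)(=O)Nc2ccc(F)c(Cl)c2)c1`) carries 3-chloro-4-fluorophenyl in place of 3-methylphenyl on a sulfonamide nitrogen and has not yet been measured. For the measured compounds named here, no measured pair isolates a change at this place. Starting from compound 3 at 41.7 nM in this assay the expectation is a slightly higher number, with no step beyond the scatter. The expected step of a 1.4-fold higher number from compound 3 to compound 4 (0.16 log units; within the scatter) is an estimate only. Compound 4 is estimated at 60 nM with an expected range from 18 nM to 200 nM in this read-out.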

Compound 4, half-maximal inhibitory concentration: 150 nM
Beside the measured number, compound 4's estimate is 2.5-fold (0.40 log units) below it, within the range that was stated.
By their numbers in this assay, from the lowest: compound 3; then compound 4; then compounds 2 and 1 (each within the scatter of the next).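

For the compounds shown here, exchanging 3-methylphenyl for 3-chloro-4-fluorophenyl on the sulfonamide nitrogen gives a 3.6-fold higher number from compound 3 to compound 4 (0.56 log units; beyond the scatter) in this assay and provides the first comparison that isolates a single change. The group on this nitrogen therefore affects the read-out, and here the exchange weakens inhibition modestly. No available evidence bears on the origin of this step.

This single pair does not show whether the shift follows from losing the methyl group, from gaining the chlorine, or from gaining the fluorine. The compounds shown leave open how 3-chlorophenyl or 4-fluorophenyl on the same nitrogen would read, and whether either would separate those contributions.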